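The source may report more compounds than this note shows. Statements on the series, on what has been measured and on what is new or still open speak of the compounds shown alone.

In a functional assay on A549 cells (Homo sapiens) for inhibition, read by MTT assay, with a stated time of 72 h (on this read-out lower numbers stand for stronger inhibition and higher numbers for weaker inhibition), three compounds sharing one core have been measured. Compound 1 (`CCCc1ccc(NC(=O)C2CCN(C/C=C/c3ccccc3)CC2)cc1`) gives 9470 nM, the lowest number of the three. Compound 2 (`COc1cccc(NC(=O)C2CCN(C/C=C/c3ccccc3)CC2)c1`) gives 50500 nM, and compound 3 (`O=C(Nc1cccc(F)c1)C1CCN(C/C=C/c2ccccc2)CC1`) gives 43300 nM.

Compound 4 (`CN1CCN(c2ccc(NC(=O)C3CCN(C/C=C/c4ccccc4)CC3)cc2)CC1`) has not yet been measured. It differs from compound 1 in one place: 4-methylpiperazin-1-yl in place of propyl on an aromatic carbon, with 4-methylpiperazin-1-yl in place of propyl on an aromatic carbon.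

The nearest evidence comes from the two steps that replace the whole 4-propylphenyl of compound 1. These are a 5.3-fold higher number from compound 1 to compound 2 (0.73 log units; beyond the scatter) and a 4.6-fold higher number from compound 1 to compound 3 (0.66 log units; beyond the scatter), both modest and both upward, while a 1.2-fold lower number from compound 2 to compound 3 (0.07 log units; within the scatter) stays within the scatter. Among the measured compounds shown here, no measured compound carries a 4-methylpiperazin-1-yl, so these steps offer only a rough scale.

A modest rise in this assay is therefore expected, somewhat smaller than those two steps. The expected change is a 2.3-fold higher number from compound 1 to compound 4 (0.37 log units; beyond the scatter). For compound 4 the estimated value is 22000 nM, with an expected range from 7000 nM to 60000 nM.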

Compound 4, half-maximal inhibitory concentration: 19900 nM
The estimate for compound 4 lay 1.1-fold (0.04 log units) above the measured number; low and high end bracket the measured number.
By their numbers in this assay, from the lowest: compound 1; then compound 4; then compounds 3 and 2 (each within the scatter of the next).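

Among the compounds shown here, compound 4 is the first compound here that keeps the place of the propyl of compound 1 and changes only the group standing on it, and in this assay the exchange for 4-methylpiperazin-1-yl gives a 2.1-fold higher number from compound 1 to compound 4 (0.32 log units; beyond the scatter). This place therefore accepts a larger group carrying a six-membered non-aromatic ring at a modest cost, although compound 1 keeps the lowest number of the four compounds. Nothing measured here bears on why the step has this size.

For the compounds shown here, with only two groups compared at this place, it remains open whether the step follows from the ring or from its nitrogens. A piperidin-1-yl or morpholin-4-yl group would separate those two readings, and a longer chain such as butyl would show whether propyl is the better chain length.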